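From hydroxy to methoxy: a short step back

This account rests on a few compounds, and the source may have more. Where it says the series, first, only, none or still open, it means among the compounds named here.

compound 1 `CCCCO[C@H](c1ccc(O)c(O)c1)[C@H](CC#Cc1ccc(O)c(O)c1)O[C@@H]1O[C@H](CO)[C@@H](O)[C@H](O)[C@H]1O`: 95.8%
compound 2 `OC[C@H]1O[C@@H](O[C@@H](CC#Cc2ccc(O)c(O)c2)[C@H](O)c2ccc(O)c(O)c2)[C@H](O)[C@@H](O)[C@@H]1O`: 84.8%

In a functional assay on heart right ventricle (Rattus norvegicus, strain WKY), tested at 1 uM (a lower number here means a stronger effect, a higher number a weaker effect of the compound at the concentration tested), compound 2 gives the lower of the two numbers. Going by the values given here, the only measured step, a number 11 percentage points lower from compound 1 to compound 2 (beyond the scatter), is the one that bears on the change considered here, since it removed an alkyl group from the same oxygen. Compound 3 `CO[C@H](c1ccc(O)c(O)c1)[C@H](CC#Cc1ccc(O)c(O)c1)O[C@@H]1O[C@H](CO)[C@@H](O)[C@H](O)[C@H]1O` now carries methyl in place of hydrogen on an oxygen on a saturated carbon. This partly reverses that step with a smaller group, so a rise of a few points, within the scatter, is expected: a number 5.2 percentage points higher from compound 2 to compound 3 (within the scatter). Compound 3 is therefore estimated at 90%, between 80% and 99%.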

Compound 3, a percentage reported as activity, at one concentration (the size of the read-out at that concentration, not a potency): 107%
For compound 3 the middle estimate is 17 percentage points below the measured one, and the stated range ends below it.
By their numbers in this assay, from the lowest: compound 2; then compound 1; then compound 3.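

In this assay, methyl on this oxygen moves the number up, a number 22.2 percentage points higher from compound 2 to compound 3 (beyond the scatter), so alkyl on the oxygen does not by itself lower the number. The number also does not follow chain length in a simple way, since the methoxy compound stands above the butyl ether, a number 11.2 percentage points higher from compound 1 to compound 3 (beyond the scatter), while the hydroxy compound 2 stands lowest. Nothing available explains this order. Open, as far as these compounds go, is how an ethyl or propyl chain on this oxygen would read, and whether an amine or a carboxylic acid at the end of such a chain would bring the number down.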